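This account rests on a few compounds, and the source may have more. Where it says the series, first, only, none or still open, it means among the compounds named here.

Compound 2 `CCCCCN1C(=O)C/C(=C\c2cccc(C(=O)NCCCC)c2)C1=O` carries a butyl group on its amide-type nitrogen. In an ADME assay on HCT-116 cells (Homo sapiens) for cytotoxicity, read by MTT assay, with a stated time of 72 h (a higher number here means a weaker inhibitor, a lower number a stronger inhibitor), compound 2 gives only a limit, > 100000 nM, and not a number, as the limit of > 100000 nM in this assay, at which 1 of the 2 values shown sits, shows. Its nearest measured neighbour, compound 1 `CCCCCN1C(=O)C/C(=C\c2cccc(C(=O)Nc3cccc(CC)c3)c2)C1=O`, gives 75300 nM in this assay. Among the measured compounds shown here, the only measured step that bears here is an at least 1.3-fold higher number from compound 1 to compound 2 (0.12 log units; that floor lies within the scatter), which sits at the floor of the scatter. Compound 3 `CCCCCN1C(=O)C/C(=C\c2cccc(C(=O)Nc3ccc(OC)cc3)c2)C1=O` differs from compound 2 by 4-methoxyphenyl in place of butyl on an amide-type nitrogen, a change that runs opposite to that measured step. A small move toward a lower number is therefore expected, an at least 1.2-fold lower number from compound 2 to compound 3 (0.09 log units; that floor lies within the scatter), but nothing beyond the scatter. Compound 3 is estimated at 80000 nM, within 35000 nM to 150000 nM.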

Compound 3, half-maximal inhibitory concentration: > 100000 nM
Compound 3 gave a limit, no number; the forecaster's own chance of this, stated with the estimate: 40%; at least 1.2-fold (0.09 log units) between middle value and limit.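

In this assay, among the compounds shown here, compound 3 gives only a limit, not a number, so 4-methoxyphenyl on this amide-type nitrogen ends up at the same limit as butyl: the limit of > 100000 nM in this assay, at which 2 of the 3 values shown sit. The one readable step is an at least 1.3-fold higher number from compound 1 to compound 3 (0.12 log units; that floor lies within the scatter), so a six-membered aromatic ring on this nitrogen does not by itself bring a measurable number. The step between the two limits cannot be read.

As far as these compounds go, how a longer chain in place of butyl, or a phenyl ring carrying an amine or a carboxylic acid, would read in this assay remains open.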